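Bombesin receptor subtype-3 agonists: aryl replacement on the benzyl arm

The source may report more compounds than this note shows. Statements on the series, on what has been measured and on what is new or still open speak of the compounds shown alone.

The measured compounds:
Compound 1 `O=C(O)c1ccccc1-c1ccc(CCc2ncc(CCC3CCCCC3)[nH]2)cc1` gives 33 nM in an in vitro functional assay on cells for agonist activity at Bombesin receptor subtype-3 (Mus musculus), read by luminescence and calcium flux; on this read-out lower numbers stand for an effect already at smaller amounts and higher numbers for an effect only at larger amounts of compound.
Compound 2 `O=C(O)c1ccccc1-c1ccc(CCc2ncc(Cc3ccc(F)cc3)[nH]2)cc1` gives 50 nM in this assay.
Compound 3 `N#Cc1ccccc1Cc1cnc(CCc2ccc(-c3ccccc3C(=O)O)cc2)[nH]1` gives 642 nM in this assay.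

Compound 3 stands at the highest number of the three. Its nearest neighbour is compound 2, a 13-fold higher number from compound 2 to compound 3 (1.11 log units; beyond the scatter), and the widest gap is to compound 1, a 19-fold higher number from compound 1 to compound 3 (1.29 log units; beyond the scatter); both steps lie beyond the scatter. Compounds 1 and 2 differ from each other only within the scatter, a 1.5-fold higher number from compound 1 to compound 2 (0.18 log units; within the scatter).

Compound 4 `Cc1ccc(Cc2cnc(CCc3ccc(-c4ccccc4C(=O)O)cc3)[nH]2)cc1` has not yet been measured in this assay. Its change from compound 3 is 4-methylphenyl in place of 2-cyanophenyl on a saturated chain carbon bound to an aromatic carbon. For the measured compounds named here, the steps that bear on it are those reaching compound 3 from the other two aryl and cyclohexyl variants: the 2-cyanophenyl group set compound 3 apart from both compound 1 and compound 2 by large margins, whereas 4-fluorophenyl and cyclohexylmethyl were within the scatter of each other. A 4-methylphenyl group resembles 4-fluorophenyl more than 2-cyanophenyl, so compound 4 is expected to move back toward compound 2, a step estimated at a 9.2-fold lower number from compound 3 to compound 4 (0.96 log units; beyond the scatter) in this assay. Compound 4 is therefore expected to give about 70 nM, with a range from 25 nM to 250 nM.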

Compound 4, half-maximal effective concentration: 162 nM
The estimate for compound 4 lay 2.3-fold (0.36 log units) below the measured number, and the stated range covers the measured number.
By their numbers in this assay, from the lowest: compounds 1 and 2 (each within the scatter of the next); then compound 4; then compound 3.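

In this assay, exchanging the 2-cyanobenzyl arm for 4-methylbenzyl recovers only part of the gap, with a 4.0-fold lower number from compound 3 to compound 4 (0.60 log units; beyond the scatter), and the number does not return to the level of the two best compounds: the steps are a 3.2-fold higher number from compound 2 to compound 4 (0.51 log units; beyond the scatter) and a 4.9-fold higher number from compound 1 to compound 4 (0.69 log units; beyond the scatter). The earlier compounds shown here had suggested a position that accepts quite different groups, since 4-fluorophenyl and cyclohexylmethyl stayed within the scatter of each other while only 2-cyanophenyl stood apart; compound 4 shows that the read-out also separates methyl from fluoro on an aromatic carbon, so a phenyl ring substituted at the 4-position does not by itself secure the lower numbers. Nothing available here accounts for this ordering of the groups.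

The compounds shown leave open whether the higher number of compound 3 follows from the nitrile itself or from where it sits on the phenyl ring, as the two change together in the step to compound 4. They also leave open how a chloro, methoxy or amino group on that ring would compare with fluoro and methyl.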